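This account rests on a few compounds, and the source may have more. Where it says the series, first, only, none or still open, it means among the compounds named here.

Working notes on the series, which shares one core and varies only the aryl group on the carbon with a double bond to nitrogen. Compound 3 `O/N=C(\CCN1CCN(c2ccccn2)CC1)c1cccc(Cl)c1` gives 73% in a functional assay on HEK293 cells with D(4) dopamine receptor (Homo sapiens) as the target, read by FLIPR; a lower number here means a smaller maximal response, a higher number a larger maximal response. Compound 1 `O/N=C(/CCN1CCN(c2ccccn2)CC1)c1ccccc1Cl` gives 64% and compound 2 `Cc1ccccc1/C(CCN1CCN(c2ccccn2)CC1)=N/O` gives 82%, so compound 3 lies between the two, and both gaps are within the scatter. Compound 4 `O/N=C(\CCN1CCN(c2ccccn2)CC1)c1ccc(Cl)cc1` differs from compound 3 in one place: 4-chlorophenyl in place of 3-chlorophenyl on a carbon with a double bond to nitrogen. Going by the values given here, the only measured step that bears on it is the exchange of the aryl group at this same carbon, a number 9 percentage points lower from compound 2 to compound 3 (within the scatter). Among the compounds with values here, no measured pair shows the move of the chlorine itself. For compound 4 a step of no change at the digits printed from compound 3 to compound 4 (within the scatter) is therefore expected, none beyond the scatter, and its estimated value is 73%, range 55% to 90%.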

Compound 4, largest response reached (reported as efficacy), in percent of the reference or control that the assay uses: 46%
Compound 4: middle estimate off by 27 percentage points, on the high side, and the stated range ends above it.
By their numbers in this assay, from the lowest: compound 4; then compounds 1, 3 and 2 (each within the scatter of the next, the first and the last beyond it).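

Moving the chlorine matters at this carbon: in this assay the step is a number 27 percentage points lower from compound 3 to compound 4 (beyond the scatter), although the atoms stay the same. The exchange of 2-methylphenyl for 4-chlorophenyl also goes beyond the scatter, at a number 36 percentage points lower from compound 2 to compound 4 (beyond the scatter), unlike the earlier aryl exchange. No available evidence bears on this result.

As far as these compounds go, it remains open whether this step is tied to chlorine itself or to any group at that ring position. Methyl, methoxy or fluorine in place of the chlorine of 4-chlorophenyl would address this.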